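The compounds below may be only part of what the source reports. "The series", "measured", "known", "first", "only" and "open" are said of these compounds alone.

Compound 1 `O=C1COc2ccc(-c3nn(-c4ccc(Br)cc4)cc3-c3ccccc3)cc2N1` and compound 2 `O=C1COc2ccc(-c3nn(-c4ccc(F)cc4)cc3-c3ccccc3)cc2N1` share one core and differ only in which halogen they carry. In a functional assay on MV4-11 cells (Homo sapiens) for cytotoxicity, read by colorimetric assay and MTT assay, with a stated time of 3 days, tested at 1 uM (on this read-out higher numbers stand for a weaker effect at the one concentration tested and lower numbers for a stronger effect), compound 1 gives 108%, and compound 2 gives 107%; the step of a number 1 percentage points lower from compound 1 to compound 2 (within the scatter) lies within the scatter, so neither compound shows a measurable effect at the one concentration tested. Compound 3 `O=C1COc2ccc(-c3nn(-c4cc(Cl)cc(Cl)c4)cc3-c3ccccc3)cc2N1` carries 3,5-dichlorophenyl in place of 4-fluorophenyl on an aromatic nitrogen. Among the compounds with values here, the only measured step that bears on this change is a number 1 percentage points lower from compound 1 to compound 2 (within the scatter), and it was flat, so no shift beyond the scatter is expected. Compound 3 is therefore estimated at 103%, within 85% to 115%. The expected step is a number 4 percentage points lower from compound 2 to compound 3 (within the scatter).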

Compound 3, a percentage reported as activity, at one concentration (the size of the read-out at that concentration, not a potency): 105%
Compound 3: middle estimate off by 2 percentage points, on the low side; the measured number falls inside the stated range.
By their numbers in this assay, from the lowest: compounds 3, 2 and 1 (each within the scatter of the next).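

On the aromatic nitrogen, 3,5-dichlorophenyl in place of 4-fluorophenyl gives a number 2 percentage points lower from compound 2 to compound 3 (within the scatter) and in place of 4-bromophenyl gives a number 3 percentage points lower from compound 1 to compound 3 (within the scatter). Two chlorine atoms at new ring places thus do not separate compound 3 from compound 2 or compound 1 in this assay, so this position now stays flat beyond a single halogen exchange. Nothing available explains this flatness.

The compounds shown leave open whether an amine or a carboxylic acid on this phenyl ring, or a longer chain in its place, would move the read-out beyond the scatter.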